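Capping the hydroxy of compound 2 with 2-bromoethyl

This account rests on a few compounds, and the source may have more. Where it says the series, first, only, none or still open, it means among the compounds named here.

compound 1 `COc1ccc(N(C)c2ccnc(Cl)n2)cc1`: 1460 nM
compound 2 `COc1ccc(N(C)c2ccnc(Cl)n2)cc1O`: 422 nM

Both values come from a functional assay on HCT-116 cells (Homo sapiens) for antiproliferative activity, read by MTT assay, with a stated time of 48 h; on this read-out lower numbers stand for stronger inhibition and higher numbers for weaker inhibition. Within the data shown here, compound 2, at 422 nM, holds the lower of the two numbers so far. Compound 3 `COc1ccc(N(C)c2ccnc(Cl)n2)cc1OCCBr` differs from it by 2-bromoethyl in place of hydrogen on an oxygen on an aromatic ring. Among the measured compounds shown here, only one measured step bears on this change: a 3.5-fold lower number from compound 1 to compound 2 (0.54 log units; beyond the scatter), a modest step that came with hydroxy in place of hydrogen on an aromatic carbon. For the measured compounds named here, no compound with a substituted oxygen of this kind has been measured, so the guide is indirect. The hydrogen of that hydroxy is lost in compound 3, so part of that gain may be given back. The expected result is a modest move to a higher number, estimated as a 2.1-fold higher number from compound 2 to compound 3 (0.33 log units; beyond the scatter). For compound 3 the estimate is 900 nM, with an expected range of 250 nM to 3000 nM.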

Compound 3, half-maximal inhibitory concentration: 5670 nM
Compound 3: the middle estimate sits 6.3-fold (0.80 log units) below what was measured, outside the stated range (above it).
By their numbers in this assay, from the lowest: compound 2; then compound 1; then compound 3.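

In this assay, among these compounds, 2-bromoethyl on this oxygen does far more than cancel the gain from the hydroxy: the result is a 13-fold higher number from compound 2 to compound 3 (1.13 log units; beyond the scatter), a large step and the first measured change at this oxygen. Against hydrogen on the aromatic carbon, the outcome is a 3.9-fold higher number from compound 1 to compound 3 (0.59 log units; beyond the scatter), so 2-bromoethoxy ends on the weaker side of the starting point rather than simply returning to it. No available measurement accounts for this loss.

With a single substituent shown on this oxygen, the loss cannot yet be assigned to the bromine, the ethyl chain or the missing hydroxy hydrogen. A plain ethyl or a 2-aminoethyl group on the same oxygen would help separate these possibilities.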